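The source may report more compounds than this note shows. Statements on the series, on what has been measured and on what is new or still open speak of the compounds shown alone.

Measured compounds:
Compound 1 `CC1CCN(C(=O)c2c(N)sc(-c3ccc(Cl)cc3)c2-c2ccc(Cl)cc2)CC1`: 5750 nM
Compound 2 `COc1ccc(CNC(=O)c2c(N)sc(-c3ccc(Cl)cc3)c2-c2ccc(Cl)cc2)cc1`: 29500 nM

In a functional assay on PC-3 cells (Homo sapiens) for inhibition, read by sulforhodamine B assay, with a stated time of 72 h (a higher number here means a weaker inhibitor, a lower number a stronger inhibitor), compound 2 stands as the higher of the two numbers at 29500 nM. Compound 3 `Nc1sc(-c2ccc(Cl)cc2)c(-c2ccc(Cl)cc2)c1C(=O)NCc1ccccc1` keeps the core of compound 2 and its amide, with hydrogen in place of methoxy on an aromatic carbon, turning 4-methoxybenzyl into benzyl: hydrogen in place of methoxy on an aromatic carbon. Within the data shown here, only one measured step is available, a 5.1-fold higher number from compound 1 to compound 2 (0.71 log units; beyond the scatter). Among the measured compounds shown here, it exchanges the whole group on the carbonyl carbon, so it bears on the present change only loosely, and no measured step removes a methoxy alone. With so little to go on, no clear direction is expected. The expected change is a 1.2-fold lower number from compound 2 to compound 3 (0.07 log units; within the scatter), which would stay within the scatter. For compound 3 the estimated value is 25000 nM, with an expected range from 10000 nM to 60000 nM.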

Compound 3, half-maximal inhibitory concentration: 31800 nM
Estimate against measurement, compound 3: 1.3-fold (0.10 log units) below, within the range that was stated.
By their numbers in this assay, from the lowest: compound 1; then compounds 2 and 3 (each within the scatter of the next).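

In this assay, hydrogen in place of methoxy gives a 1.1-fold higher number from compound 2 to compound 3 (0.03 log units; within the scatter) and so leaves the two groups indistinguishable at this aromatic carbon, para to a large group. Against compound 1, the benzylamino amide gives a 5.5-fold higher number from compound 1 to compound 3 (0.74 log units; beyond the scatter) and thus keeps the gap already seen with the (4-methoxybenzyl)amino amide, which shows that this gap does not depend on the methoxy. Nothing available gives a measured reason for either result.

As far as these compounds go, what an amine or a carboxylic acid on this aromatic carbon would do remains open, since methoxy and hydrogen alone cannot show whether the position tolerates every group. Also open, from the compounds shown here alone, is whether a longer chain, such as phenethylamino in place of benzylamino, would move the number towards that of compound 1 or leave it where compound 3 stands.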